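Series notes: urea variants on a shared diaryl ether core

The compounds below may be only part of what the source reports. "The series", "measured", "known", "first", "only" and "open" are said of these compounds alone.

Measured compounds:
compound 1 `O=C(Nc1ccc(Oc2ccc(-c3nccs3)cc2)cc1)Nc1cccc(C(F)(F)F)c1` – 71.5%
compound 2 `O=C(Nc1ccc(Oc2ccc(-c3nccs3)cc2)cc1)Nc1cc(Br)cc(C(F)(F)F)c1` – 81.7%

In a functional assay on A549 cells (Homo sapiens) for inhibition, read by MTT assay and WST assay, with a stated time of 72 h, tested at 10 uM (on this read-out higher numbers stand for more inhibition of growth at the one concentration tested and lower numbers for less inhibition of growth), compound 1 gives 71.5% and compound 2 gives 81.7%. For the measured compounds named here, compound 2 stands highest of the two, and its only comparator is compound 1; the step of a number 10.2 percentage points higher from compound 1 to compound 2 (beyond the scatter) accompanies bromo in place of hydrogen on an aromatic carbon. Compound 3 `CC(=O)Oc1sccc1NC(=O)Nc1ccc(Oc2ccc(-c3nccs3)cc2)cc1` differs from compound 2 by 2-acetoxythiophen-3-yl in place of 3-bromo-5-(trifluoromethyl)phenyl on an amide-type nitrogen. Going by the values given here, no measured step covers such an exchange on the amide-type nitrogen; the single step on record is modest and concerns a small substituent, so it bears on compound 3 only weakly. With the whole aryl group exchanged, a change larger than the scatter is expected, more likely downward, as a number 26.7 percentage points lower from compound 2 to compound 3 (beyond the scatter). For compound 3 the estimated value in this assay is 55%, within 25% to 80%.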

Compound 3, percent growth inhibition at one concentration: 6.78%
The estimate for compound 3 lay 48.2 percentage points above the measured number; the measured number lies below the stated range.
By their numbers in this assay, from the lowest: compound 3; then compound 1; then compound 2.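

At the amide-type nitrogen, the choice of the whole aryl group matters far more than the bromo substituent did. In this assay, 2-acetoxythiophen-3-yl in place of 3-bromo-5-(trifluoromethyl)phenyl gives a number 74.9 percentage points lower from compound 2 to compound 3 (beyond the scatter), and in place of 3-(trifluoromethyl)phenyl it gives a number 64.7 percentage points lower from compound 1 to compound 3 (beyond the scatter), both large steps. No measurement at hand accounts for this loss.

The compounds shown leave open whether the loss follows the thiophene ring or the acetoxy group, as both enter together. A plain thiophen-3-yl and an acetoxyphenyl group would separate the two.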